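The compounds below may be only part of what the source reports. "The series", "measured", "known", "first", "only" and "open" are said of these compounds alone.

Compound 1 `NS(=O)(=O)c1ccc(CNc2nc(Nc3cccc(NC(=O)N4CCCC4)c3)ncc2Br)cc1`: > 10000 nM
Compound 2 `NS(=O)(=O)c1ccc(CNc2ccnc(Nc3cccc(NC(=O)N4CCCC4)c3)n2)cc1`: > 10000 nM
Compound 3 `O=C(NCCCNc1ccnc(Nc2cccc(NC(=O)N3CCCC3)c2)n1)C1CCC1`: > 10000 nM

In an assay on HEK293 cells for displacement of a labelled ligand from MAP/microtubule affinity-regulating kinase 3 (Homo sapiens), read by NanoBRET (a higher number here means a weaker inhibitor, a lower number a stronger inhibitor), compound 2 gives > 10000 nM, which is a limit of the assay and not a number. Compound 1 also gives a limit in this assay, > 10000 nM. Compound 3 likewise gives a limit, > 10000 nM. Both measured steps, a step that the two limits leave unreadable from compound 1 to compound 2 and a step that the two limits leave unreadable from compound 2 to compound 3, cannot be sized because of the limit of > 10000 nM in this assay, at which 3 of the 3 values shown sit. Compound 4 `NS(=O)(=O)c1ccc(CNc2nc(Nc3cccc(NC(=O)N4CCCC4)c3)ncc2C2CC2)cc1` differs from compound 2 in one place: cyclopropyl in place of hydrogen on an aromatic carbon. Going by the values given here, no measured step reads on this change, and compound 1 shows that another group at this position also sits at a limit. The expected step that the limit leaves unreadable from compound 2 to compound 4 is therefore estimated as none beyond the scatter. Compound 4 is expected at 15000 nM, with a range from 3000 nM to 60000 nM.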

Compound 4, half-maximal inhibitory concentration: > 10000 nM
Compound 4 gave a limit, no number (the forecaster's own chance of this, stated with the estimate: 75%); the middle value lies beyond the limit too.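

Neither step to compound 4, from compound 2 or from compound 1, can be read in this assay, because the values are limits and not numbers: the limit of > 10000 nM in this assay, at which 4 of the 4 values shown sit.

The compounds shown leave open how hydrogen, bromo and cyclopropyl on this aromatic carbon compare.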